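This account rests on a few compounds, and the source may have more. Where it says the series, first, only, none or still open, it means among the compounds named here.

Working notes on the series. Compound 1 `CC1=C(/C=C/C(=O)/C=C/c2ccccc2)C(C)(C)CCC1` gives 10600 nM in a functional assay on MCF7 cells (Homo sapiens) for cytotoxicity, read by sulforhodamine B assay, with a stated time of 48 h; on this read-out lower numbers stand for stronger inhibition and higher numbers for weaker inhibition. Compound 2 `COc1ccccc1/C=C/C(=O)/C=C/C1=C(C)CCCC1(C)C` carries methoxy in place of hydrogen on an aromatic carbon on the core of compound 1; compound 2 gives 13400 nM, and the step is a 1.3-fold higher number from compound 1 to compound 2 (0.10 log units; within the scatter). Compound 3 `CC1=C(/C=C/C(=O)/C=C/C=C/c2ccccc2)C(C)(C)CCC1` is built on a different core, and the difference between the two cores is not broken down here; compound 3 gives 46700 nM, the highest number of the three, beyond the scatter from both compound 1 and compound 2. Compound 4 `COc1ccccc1/C=C/C=C/C(=O)/C=C/C1=C(C)CCCC1(C)C` carries methoxy in place of hydrogen on an aromatic carbon on the core of compound 3, the same change as from compound 1 to compound 2, at the same place. For the measured compounds named here, the only precedent for this change is the step from compound 1 to compound 2, which stayed within the scatter, so a step of similar size is expected, a 1.2-fold higher number from compound 3 to compound 4 (0.07 log units; within the scatter), resting on compound 3 at 46700 nM. Compound 4 is therefore estimated at 55000 nM, with a range from 25000 nM to 120000 nM.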

Compound 4, half-maximal inhibitory concentration: 55400 nM
The estimate for compound 4 lay 1.0-fold (0.00 log units) below the measured number, within the range that was stated.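

In this assay the change from phenyl to 2-methoxyphenyl on the core of compound 3 gives a 1.2-fold higher number from compound 3 to compound 4 (0.07 log units; within the scatter) and agrees with the earlier step on the core of compound 1: the same change on two cores in this assay, a 1.3-fold higher number (0.10 log units; within the scatter) from compound 1 to compound 2 and a 1.2-fold higher number (0.07 log units; within the scatter) from compound 3 to compound 4, 1.1-fold (0.03 log units) apart, within the scatter of two such steps. The change therefore carries across these two cores, with neither step beyond the scatter. For the compounds shown here, this rests on only two pairs, shows no gain or loss from methoxy on either core, and does not extend to any other core.

Still open, on these data alone, is whether a group other than methoxy, such as an amine, a carboxylic acid or a longer alkoxy chain, would behave alike in that place. Also open, as far as these compounds go, is how methoxy would read at other places on the aromatic ring.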